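The source may hold more compounds than are shown below. What is called first, only, known or untested is meant among the compounds shown, and "the series" means these compounds.

Measured so far:
- compound 1, `Cn1nc2c(=O)n(CC3(O)CCN(Cc4ccc(-c5ccco5)cc4Cl)CC3)cnc2c1-c1ccc(C2(N)CC2)cc1`: 66.1 nM
- compound 2, `Cn1nc2c(=O)n(CC3(O)CCN(Cc4ccc(C5CCCO5)cc4Cl)CC3)cnc2c1-c1ccc(CN)cc1`: 3820 nM

In an assay on isolated protein for inhibition of ubiquitin carboxyl-terminal hydrolase 7 (Homo sapiens), with stated times of 30 min and 2 h (a lower number here means a stronger inhibitor, a higher number a weaker inhibitor), compound 1 gives 66.1 nM, while compound 2 gives 3820 nM, the higher of the two numbers and well beyond the scatter from compound 1. Compound 1 and compound 2 differ in more than one place, so only their two values can be compared. Compound 3, `Cn1nc2c(=O)n(CC3(O)CCN(Cc4ccc(-c5cccs5)cc4Cl)CC3)cnc2c1-c1ccc(CN)cc1`, is not yet measured. It differs from compound 2 in one place: thiophen-2-yl in place of oxolan-2-yl on an aromatic carbon. Within the data shown here, since no single-change step is known here, the direction is uncertain, but a move toward lower numbers is expected for compound 3, with a 6.4-fold lower number from compound 2 to compound 3 (0.80 log units; beyond the scatter) as the estimated step. Compound 3 is expected to give 600 nM, in the range 120 nM to 3000 nM.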

Compound 3, half-maximal inhibitory concentration: 38.6 nM
Compound 3: the middle estimate sits 16-fold (1.19 log units) above what was measured; the whole stated range lies above it.
By their numbers in this assay, from the lowest: compounds 3 and 1 (each within the scatter of the next); then compound 2.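

In this assay the change from oxolan-2-yl to thiophen-2-yl gives a 99-fold lower number from compound 2 to compound 3 (2.00 log units; beyond the scatter) and shows that this position, para to a large group, responds strongly to the ring placed there. The two rings have the same counts of heavy atoms, hydrogen-bond donors and acceptors, but one is aromatic with sulfur and the other non-aromatic with oxygen. No measurement at hand explains the size of this step. Still open, going by these compounds, is whether aromaticity or sulfur matters more: thiolan-2-yl, a non-aromatic sulfur ring, would help separate the two.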